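From a cyclopropyl amide to an isopropyl urea

This account rests on a few compounds, and the source may have more. Where it says the series, first, only, none or still open, it means among the compounds named here.

Compound 1 `CCC(C)(C)C(=O)Nc1ccc2nc(NC(=O)C3CCCCC3)sc2c1` gives 1 ug/mL in a functional assay on WI-38 VA13 cells (Homo sapiens) for cytotoxicity; a higher number here means that more compound is needed for the effect, a lower number that less compound is needed.
Compound 2 `Cc1cc(C(=O)Nc2ccc3nc(NC(=O)C4CCCCC4)sc3c2)n(C)n1` gives 0.12 ug/mL.
Compound 3 `O=C(Nc1ccc2nc(NC(=O)C3CC3)sc2c1)c1c(Cl)cccc1Cl` gives 0.013 ug/mL.

Among these three, compound 3 gives the lowest number, so the least of it is needed for the effect. Compound 2 comes nearest to it, and compound 1 lies furthest away; both of those gaps are beyond the scatter of repeated measurements.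

Compound 4 `CC(C)NC(=O)Nc1nc2ccc(NC(=O)c3c(Cl)cccc3Cl)cc2s1` is compound 3 with one change: isopropylamino in place of cyclopropyl on a carbonyl carbon. For the measured compounds named here, the only measured step, an 8.3-fold lower number from compound 1 to compound 2 (0.92 log units; beyond the scatter), concerns a group on a different carbonyl carbon, so no measured step speaks directly to this change. That step shows that swapping a group on a carbonyl carbon can move the number well beyond the scatter, but it gives no direction for the present swap. The expectation for compound 4 is therefore built with wide uncertainty around the value of compound 3. Compound 4 is estimated at 0.04 ug/mL, with a likely range from 0.008 ug/mL to 0.2 ug/mL. This estimate corresponds to an expected step of a 3.1-fold higher number from compound 3 to compound 4 (0.49 log units; beyond the scatter).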

Compound 4, half-maximal effective concentration: 0.03 ug/mL
Compound 4: middle estimate off by 1.3-fold (0.12 log units), on the high side; measured number inside the range.
By their numbers in this assay, from the lowest: compound 3; then compound 4; then compound 2; then compound 1.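

In this assay, for the compounds shown here, the first measured change at this place, isopropylamino in place of cyclopropyl on a carbonyl carbon whose other neighbour is an amide-type nitrogen, gives a 2.3-fold higher number from compound 3 to compound 4 (0.36 log units; beyond the scatter). The step is modest but real, so this place responds to the swap without the number rising far: a ring of carbon gives way to an open group that brings one nitrogen and one hydrogen-bond donor. No measurement here explains why the number moves.

Going by these compounds alone, the single step changes the ring and the nitrogen together, so their separate shares stay open; cyclopropylamino would keep the ring with the nitrogen, and isopropyl would keep the branched carbons without it. On these data alone, whether the swap moves the number as much with another group on the other carbonyl also remains unknown.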